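The compounds below may be only part of what the source reports. "The series", "measured", "known", "first", "only" and "open" are said of these compounds alone.

- compound 1 `CC(C)C1=C(C(=O)N2[C@H](C)CC[C@H]2C(=O)N2CCN(C)C3(CC3)C2)SC2=N[C@@](C)(c3ccc(Cl)cc3)[C@@H](c3ccc(Cl)cc3)N21` gives 38 ug/mL
- compound 2 `CC(C)C1=C(C(=O)N2[C@H](C)CC[C@H]2C(=O)N2CCNC3(CC3)C2)SC2=N[C@@](C)(c3ccc(Cl)cc3)[C@@H](c3ccc(Cl)cc3)N21` gives 56 ug/mL

Both numbers come from a physicochemical assay for solubility, read by HPLC, in phosphate buffer, at pH 6.8, tested at 10 mM (on this read-out higher numbers stand for higher solubility and lower numbers for lower solubility), and lie within the usual scatter of each other, so the data do not separate compound 2 from compound 1. Compound 3 `CC(C)C1=C(C(=O)N2[C@H](C)CC[C@H]2C(=O)N2CCNC3(CC3)C2)SC2=N[C@@](C)(c3ccc(Cl)cc3)[C@@H](c3ccc(Cl)c(F)c3)N21` matches compound 2 except for one change: fluoro in place of hydrogen on an aromatic carbon that is, fluoro in place of hydrogen on an aromatic carbon, turning 4-chlorophenyl into 4-chloro-3-fluorophenyl. For the measured compounds named here, the only measured step is a 1.5-fold higher number from compound 1 to compound 2 (0.17 log units; within the scatter) and it lies within the scatter. That step is hydrogen in place of methyl on an amine nitrogen in a ring, so it bears only loosely on this change. Going by the values given here, no measured step covers fluoro on an aromatic carbon, and no step beyond the scatter is expected in this assay here. The expected step is a 1.1-fold lower number from compound 2 to compound 3 (0.05 log units; within the scatter) and stays within the scatter. For compound 3 the estimated value is 50 ug/mL with an expected range from 22 ug/mL to 110 ug/mL in this assay.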

Compound 3, solubility: 51 ug/mL
Estimate against measurement, compound 3: 1.0-fold (0.01 log units) below; measured number inside the range.
By their numbers in this assay, from the lowest: compounds 1, 3 and 2 (each within the scatter of the next).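

In this assay, fluoro in place of hydrogen on this aromatic carbon, which turns 4-chlorophenyl into 4-chloro-3-fluorophenyl, gives a 1.1-fold lower number from compound 2 to compound 3 (0.04 log units; within the scatter), so the data do not separate the two compounds. For the compounds shown here, the earlier step concerned only the amine nitrogen, whereas this one is the first reading on the aromatic ring: at this place, ortho to a chloro group, a single fluorine atom leaves no measurable mark on the number. Nothing available explains this result or shows what the fluoro group does within the molecule.

Going by these compounds, it remains open whether a methoxy group, a nitrile or an amine at this same carbon would move the number beyond the scatter. Also open, on these data alone, is whether fluoro on the other 4-chlorophenyl group would read the same way.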